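This account rests on a few compounds, and the source may have more. Where it says the series, first, only, none or still open, it means among the compounds named here.

In an assay on isolated protein for inhibition of acid ceramidase (Homo sapiens), read by LC-MS, with a stated time of 1 h (a lower number here means a stronger inhibitor, a higher number a weaker inhibitor), compound 1 `O=C(NCCCCc1ccccc1)n1c(-c2ccccc2)coc1=O` gives 70 nM, which is the higher of the two numbers recorded so far. For the measured compounds named here, compound 2 `CCCCCNC(=O)n1c(-c2ccccc2)coc1=O` gives 25 nM in this assay, and the step of a 2.8-fold lower number from compound 1 to compound 2 (0.45 log units; beyond the scatter) carries the only measured comparison, a methyl in place of phenyl on a saturated chain carbon, four bonds along the chain from an amide-type nitrogen.

Compound 3 `Cc1oc(=O)n(C(=O)NCCCCc2ccccc2)c1-c1ccccc1` differs from compound 1 elsewhere, by the change (methyl in place of hydrogen on an aromatic carbon), a methyl in place of hydrogen on an aromatic carbon of the shared core. Going by the values given here, no measured step touches this part of the structure: the single step in this assay concerns the chain, not the ring, and so gives no direct guide to the size or direction of the change at the ring carbon. Nothing recorded therefore suggests a step beyond the scatter in this assay for compound 3, though the missing information leaves the range wide in both directions.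

On that basis compound 3 is expected to give about 70 nM in this assay, with a range from 25 nM to 200 nM, corresponding to an expected step of no change at the digits printed from compound 1 to compound 3 (within the scatter).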

Compound 3, half-maximal inhibitory concentration: 42 nM
Compound 3: middle estimate off by 1.7-fold (0.22 log units), on the high side, within the range that was stated.
By their numbers in this assay, from the lowest: compounds 2, 3 and 1 (each within the scatter of the next, the first and the last beyond it).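

In this assay, the methyl in place of hydrogen on an aromatic carbon, next to the ring oxygen and next to the ring atom that bears a phenyl group, gives a 1.7-fold lower number from compound 1 to compound 3 (0.22 log units; within the scatter). For the compounds shown here, the only earlier step, a 2.8-fold lower number from compound 1 to compound 2 (0.45 log units; beyond the scatter), concerned the chain and lay beyond the scatter, so this is the first reading at the shared core, and it shows that a single methyl at this ring carbon can be carried without a step beyond the scatter. No measurement at hand gives a reason for this result at this position.

Going by these compounds, what remains open is whether a larger group at the same aromatic carbon, such as an ethyl, or a different kind of group, such as a chlorine atom or a carboxylic acid, would also stay within the scatter of compound 1 or would move the number beyond it. On these data alone, it is equally open whether the methyl would give a similar step when placed on the core of compound 2, which carries the shorter chain without the phenyl group.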